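The source may hold more compounds than are shown below. What is called first, only, known or untested is meant among the compounds shown, and "the series" means these compounds.

Working notes on the series. For the measured compounds named here, compound 3 `Cc1cc(C)c(S(=O)(=O)N2CCC(N3CCC(O)CC3)CC2)c(C)c1` gives 106 nM in a functional assay on DLD-1 cells (Homo sapiens) for antiproliferative activity, read by CellTiter-Glo, with a stated time of 72 h (a lower number here means a stronger inhibitor, a higher number a weaker inhibitor), the second highest of the three numbers so far. Compound 2 `Cc1cc(C)c(S(=O)(=O)N2CCC(N3CCC(C(C)C)CC3)CC2)c(C)c1` gives 0.3 nM, and compound 1 `Cc1ccc(C2CCN(S(=O)(=O)c3c(C)cc(C)cc3C)CC2)cc1` gives 2200 nM. The steps that frame compound 3 are both large: a 350-fold higher number from compound 2 to compound 3 (2.55 log units; beyond the scatter), and a 21-fold lower number from compound 1 to compound 3 (1.32 log units; beyond the scatter). The further step a 7300-fold lower number from compound 1 to compound 2 (3.87 log units; beyond the scatter) shows how far the series stretches when the saturated ring bearing a nitrogen carries the isopropyl group.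

Compound 4 `Cc1cc(C)c(S(=O)(=O)N2CCC(C3OCC(C)CO3)CC2)c(C)c1` is not yet measured. The change from compound 3 is a group of 7 heavy atoms (5 carbon, 2 oxygen; one six-membered non-aromatic ring with 2 hetero atoms) in place of a group of 7 heavy atoms (5 carbon, 1 nitrogen, 1 oxygen; one six-membered non-aromatic ring with 1 hetero atom), on a saturated ring carbon. Neither listed step matches it directly. The group that enters has no ring nitrogen, which places compound 4 nearer to compound 1 than to compound 2 in that respect, and compound 1 sits at the weak end with 2200 nM. A step beyond the scatter toward a higher number is therefore expected in this assay, in the order of a 14-fold higher number from compound 3 to compound 4 (1.15 log units; beyond the scatter). For compound 4 the estimate in this assay is 1500 nM, with a range from 300 nM to 8000 nM.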

Compound 4, half-maximal inhibitory concentration: > 5000 nM
Compound 4: a limit, no number; the forecaster's own chance of this, stated with the estimate: 10%; middle value at least 3.3-fold (0.52 log units) from the limit.
By their numbers in this assay, from the lowest: compound 2; then compound 3; then compound 1. At a limit, above all of these: compound 4.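

In this assay the reading for compound 4 is a limit and not a number: the limit of > 5000 nM in this assay, at which 1 of the 4 values shown sits. At this saturated ring carbon, the group of 7 heavy atoms with 2 ring oxygens and no nitrogen gives an at least 47-fold higher number from compound 3 to compound 4 (1.67 log units; beyond the scatter) and an at least 16000-fold higher number from compound 2 to compound 4 (4.22 log units; beyond the scatter), so a matching heavy-atom count in the group does not preserve the activity of 4-hydroxypiperidin-1-yl. The step of an at least 2.2-fold higher number from compound 1 to compound 4 (0.35 log units; beyond the scatter) then leaves the two groups without nitrogen, the 4-methylphenyl and the new ring, with the highest numbers among the four compounds, and no compound shown goes against this.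

The compounds shown do not separate the nitrogen from the other differences between these groups. A cyclohexyl group carrying hydroxy or isopropyl, or a piperidin-1-yl group carrying a carboxylic acid or an amine, would bear on that question.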